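Swapping the Amide Side Chain of Compound 1

The compounds below may be only part of what the source reports. "The series", "measured", "known", "first", "only" and "open" are said of these compounds alone.

Going by the values given here, compound 1 (`CC1=C(CC(=O)N(C)CCN(C)C)c2cc(F)ccc2/C1=C\c1nc2ccccc2s1`) is the only compound here with a numerical result. In a functional assay on PC-3 cells (Homo sapiens) for inhibition, read by CellTiter-Glo, with a stated time of 72 h (a higher number here means that more compound is tolerated, a lower number that less compound is tolerated), compound 1 gives 5880 nM. Compound 2 (`CC1=C(CC(=O)NCCN(C)C)c2cc(F)ccc2/C1=C\c1ccc(S(C)(=O)=O)cc1`) has no numerical result in this assay, and its > 50000 nM is a limit of the assay. Compound 1 therefore offers the single numerical reference point for what follows.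

Compound 3 (`CC1=C(CC(=O)N2CCN(CCCN(C)C)CC2)c2cc(F)ccc2/C1=C\c1nc2ccccc2s1`) keeps the core of compound 1 and changes only the group on a carbonyl carbon whose other neighbour is a saturated chain carbon. There, 4-(3-(dimethylamino)propyl)piperazin-1-yl stands in place of (2-(dimethylamino)ethyl)(methyl)amino (4-(3-(dimethylamino)propyl)piperazin-1-yl in place of (2-(dimethylamino)ethyl)(methyl)amino on a carbonyl carbon). The entering group brings one six-membered non-aromatic ring, and neither group has a net charge.

Among the compounds with values here, no measured pair of compounds shows what this exchange does. The expectation in this assay is therefore anchored on compound 1 at 5880 nM, with no step beyond the scatter expected and a slight lean towards a lower number. The expected change is a 1.7-fold lower number from compound 1 to compound 3 (0.23 log units; within the scatter). Compound 3 is estimated at 3500 nM, with an expected range of 1200 nM to 12000 nM.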

Compound 3, half-maximal cytotoxic concentration: 4210 nM
Beside the measured number, compound 3's estimate is 1.2-fold (0.08 log units) below it, within the range that was stated.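

In this assay, putting 4-(3-(dimethylamino)propyl)piperazin-1-yl in place of (2-(dimethylamino)ethyl)(methyl)amino on a carbonyl carbon gives a 1.4-fold lower number from compound 1 to compound 3 (0.15 log units; within the scatter). Going by these compounds alone, this is the first measured step at this position, and it shows that the larger entering group, with its six-membered non-aromatic ring, leaves the number within the scatter of compound 1 while the rest of the structure stays the same. Compound 3 thus gives a number and not a limit, whereas compound 2 is the one compound that stands at a limit, and as it differs from compound 1 in more than one place it sets no step for this exchange: the limit of > 50000 nM in this assay, at which 1 of the 3 values shown sits.

What the compounds shown leave open is whether a simple morpholin-4-yl group, a primary amine or a carboxylic acid at the end of the chain on the same carbonyl carbon would also stay within the scatter of compound 1, or would move the number beyond it. On these data alone, with a single step at this position, no trend in chain length or ring can be drawn, and it remains open whether the terminal dimethylamino group has any part in the result.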